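A few compounds are considered here, and "the series" means these few. Any claim that something is new, unique, unknown or untested is made for them only; others in the source may bear on it.

Measured so far in a functional assay on Raji cells (Homo sapiens) for antiproliferative activity, read by MTT assay, with a stated time of 48 h; on this read-out lower numbers stand for stronger inhibition and higher numbers for weaker inhibition:
- compound 1 `CN(C)CCn1c(N)c(-c2nc3ccccc3[nH]2)c2nc(C#N)c(C#N)nc21` gives 8320 nM
- compound 2 `N#Cc1nc2c(-c3nc4ccccc4[nH]3)c(N)n(CCCO)c2nc1C#N` gives > 50000 nM as a limit of the assay, not a number
- compound 3 `CN(C)CCn1c(N)c(-c2nc3cc(Cl)ccc3[nH]2)c2nc(C#N)c(C#N)nc21` gives 11800 nM

Compound 3 sits within the scatter of compound 1, with a 1.4-fold higher number from compound 1 to compound 3 (0.15 log units; within the scatter) as the chloro step.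

Compound 4 `CN(C)CCCCn1c(N)c(-c2nc3cc(Cl)ccc3[nH]2)c2nc(C#N)c(C#N)nc21` carries 2-(dimethylamino)ethyl in place of dimethylamino on a saturated chain carbon, two bonds along the chain from an aromatic nitrogen, counted as 2-(dimethylamino)ethyl in place of dimethylamino on a saturated chain carbon, two bonds along the chain from an aromatic nitrogen in full.

Among the measured compounds shown here, one measured step touches this place, an at least 6.0-fold higher number from compound 1 to compound 2 (0.77 log units; beyond the scatter) for hydroxymethyl, but that change removes the dimethylamino that compound 4 keeps. For the measured compounds named here, no measured pair lengthens the chain alone, so no clear direction is expected.

The expected step is a 1.2-fold lower number from compound 3 to compound 4 (0.07 log units; within the scatter) and would lie within the scatter.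

For compound 4 the estimated value is 10000 nM with an expected range from 3000 nM to 35000 nM in this assay for now.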

Compound 4, half-maximal inhibitory concentration: 950 nM
Compound 4: middle estimate off by 11-fold (1.02 log units), on the high side; the measured number lies below the stated range.
By their numbers in this assay, from the lowest: compound 4; then compounds 1 and 3 (each within the scatter of the next). At a limit, above all of these: compound 2.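

With the dimethylamino kept, going from 2-(dimethylamino)ethyl to 4-(dimethylamino)butyl gives a 12-fold lower number from compound 3 to compound 4 (1.09 log units; beyond the scatter) in this series, so chain length at this position alone moves the read-out. Among the compounds shown here, the earlier steps showed only a loss of activity on replacing dimethylamino with hydroxymethyl and a chloro step within the scatter; this is the first change to lower the number beyond the scatter. Nothing shown accounts for the size of this step.

From the compounds shown here alone, whether 3-(dimethylamino)propyl or a longer chain carrying dimethylamino does better remains open. Also open, going by these compounds, is whether the 4-(dimethylamino)butyl gain holds without the chloro, or with a piperidine in place of dimethylamino.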